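Demethylation at the saturated ring carbon: clearance notes

The compounds below may be only part of what the source reports. "The series", "measured", "known", "first", "only" and "open" are said of these compounds alone.

Measured so far in an ADME assay on microsomes from liver (Mus musculus) for metabolic stability, read by LC-MS, using NADPH, with stated times of 10 min and 30 min; on this read-out lower numbers stand for slow clearance and higher numbers for fast clearance:
compound 1 `CC1(C)c2cc(Cl)ccc2C(=O)N1c1cccnc1`: 25 mL/min/kg
compound 2 `CC1c2cc(Cl)ccc2C(=O)N1c1cccnc1`: 66.5 mL/min/kg
compound 3 `CC(=O)N[C@@H]1CCCc2c1cncc2N1C(=O)c2ccc(Cl)cc2[C@H]1C`: 43.5 mL/min/kg

Compound 1 and compound 2 share a core and differ in one place (hydrogen in place of methyl on a saturated ring carbon). In this assay the step is a 2.7-fold higher number from compound 1 to compound 2 (0.42 log units; beyond the scatter), so removing the methyl from this position moved the number beyond the scatter.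

Compound 3 carries a different core; how the two cores differ is not broken down here. In this assay compound 3 gives 43.5 mL/min/kg, which sits within the scatter of compound 2 and also within the scatter of compound 1, so no order among these three is asserted beyond the step from compound 1 to compound 2.

Compound 4 `CC(=O)N[C@@H]1CCCc2c1cncc2N1Cc2cc(Cl)ccc2C1=O` has not yet been measured. It differs from compound 3 by hydrogen in place of methyl on a saturated ring carbon. This is the same kind of change as that from compound 1 to compound 2; the surroundings differ only in that the neighbouring ring atom bears a large group in compound 3 rather than the pyridin-3-yl group of compound 1.

For compound 4 in this assay a step of a 2.1-fold higher number from compound 3 to compound 4 (0.32 log units; beyond the scatter) is expected, resting on the single earlier case because a 2.7-fold higher number from compound 1 to compound 2 (0.42 log units; beyond the scatter) went in the same direction for the same kind of change. The pair of compounds 1 and 2 is the only basis, so the range is kept wide. Compound 4 is therefore estimated at 90 mL/min/kg, expected to lie between 45 mL/min/kg and 180 mL/min/kg.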

Compound 4, clearance: < 20.2 mL/min/kg
Compound 4: only a limit was reported; the forecaster's own chance of this, stated with the estimate: 5%; at least 4.4-fold (0.64 log units) between middle value and limit.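

Replacing methyl with hydrogen on the saturated ring carbon gives, in this assay, an at least 2.1-fold lower number from compound 3 to compound 4 (0.33 log units; beyond the scatter), so the change does not carry over from the core of compound 1 to the core of compound 3 with the same direction: the same change on two cores in this assay, a 2.7-fold higher number (0.42 log units; beyond the scatter) from compound 1 to compound 2 and an at least 2.1-fold lower number (0.33 log units; beyond the scatter) from compound 3 to compound 4, at least 5.7-fold (0.75 log units) apart, beyond the scatter of two such steps

Compound 4 gives < 20.2 mL/min/kg, which is a limit of the assay and not a number.

These two pairs show that the result of this change on one core did not predict its result on the other in this series, but they do not show which difference between the cores goes with the reversal, nor what the change would do on any further core.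

The compounds shown leave open how an ethyl group or a fluorine atom on the same saturated ring carbon would read in this assay, and whether two methyl groups there would give the core of compound 3 a lower or a higher number than the single methyl of compound 3. They also leave open whether the reversal persists when the large group on the ring atom that bears it is replaced by a free amine or a carboxylic acid.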